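The source may hold more compounds than are shown below. What is called first, only, known or untested is meant among the compounds shown, and "the series" means these compounds.

In an ADME assay on HeLa cells (Homo sapiens) for cytotoxicity, read by resazurin assay, with a stated time of 2 days (a higher number here means a weaker inhibitor, a lower number a stronger inhibitor), compound 1 `Cn1c([N+](=O)[O-])cnc1/C=C/c1ccccc1` gives > 100000 nM, which is a limit of the assay and not a number. In the same read-out, compound 2 `Cc1ccccc1/C=C/c1ncc([N+](=O)[O-])n1C` gives 93300 nM, and compound 3 `Cc1cccc(/C=C/c2ncc([N+](=O)[O-])n2C)c1` gives 30900 nM. Compound 4 `Cn1c([N+](=O)[O-])cnc1/C=C/c1ccc(OC(F)(F)F)cc1` differs from compound 1 by trifluoromethoxy in place of hydrogen on an aromatic carbon. The closest measured changes are methyl in place of hydrogen on an aromatic carbon: an at least 1.0-fold lower number from compound 1 to compound 2 (0.03 log units; that floor lies within the scatter) stays within the scatter, while an at least 3.2-fold lower number from compound 1 to compound 3 (0.51 log units; beyond the scatter) goes beyond it. Both are floors set by the limit of compound 1, and neither involves trifluoromethoxy. A modest move to a lower number in this assay is therefore expected, with the expected step being an at least 2.5-fold lower number from compound 1 to compound 4 (0.39 log units; beyond the scatter). For compound 4 the estimated value is 40000 nM, with an expected range of 12000 nM to 100000 nM.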

Compound 4, half-maximal inhibitory concentration: 83200 nM
Compound 4: middle estimate off by 2.1-fold (0.32 log units), on the low side, and the stated range covers the measured number.
By their numbers in this assay, from the lowest: compound 3; then compounds 4 and 2 (each within the scatter of the next). At a limit, above all of these: compound 1.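

In this assay, trifluoromethoxy on an aromatic carbon para to a large group gives an at least 1.2-fold lower number from compound 1 to compound 4 (0.07 log units; that floor lies within the scatter), so this position takes a group of 5 heavy atoms with no step shown beyond the scatter. Compound 1 gives > 100000 nM, which is a limit of the assay and not a number. The step is therefore only a floor, and its true size cannot be read, because compound 1 stands at that limit: the limit of > 100000 nM in this assay, at which 1 of the 4 values shown sits.

Open, as far as these compounds go, is how an amine, a carboxylic acid or a longer chain at this same position would move the number.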